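A few compounds are considered here, and "the series" means these few. Any claim that something is new, unique, unknown or untested is made for them only; others in the source may bear on it.

Among the compounds with values here, in a functional assay on MCF7 cells (Homo sapiens) for antiproliferative activity, read by MTT assay, with a stated time of 48 h (on this read-out higher numbers stand for weaker inhibition and lower numbers for stronger inhibition), compound 2 `O=C(/C=C/c1ccccc1)Nc1cc2c(Nc3cccc(Cl)c3F)ncnc2s1` gives 93900 nM, the highest of the two numbers measured so far, while compound 1 `O=C(/C=C/c1ccccc1)Nc1cc2c(Nc3ccc(F)c(Cl)c3)ncnc2s1` gives 14300 nM. Compound 3 `O=C(/C=C/c1ccccc1)Nc1cc2c(Nc3cc(Cl)cc(Cl)c3)ncnc2s1` differs from compound 2 by 3,5-dichlorophenyl in place of 3-chloro-2-fluorophenyl on a nitrogen on an aromatic ring. Within the data shown here, the only measured step bearing on this change is a 6.6-fold higher number from compound 1 to compound 2 (0.82 log units; beyond the scatter), which shows that altering the halogen pattern on this ring shifts the number modestly. One therefore expects a modest move toward a lower number for compound 3, estimated as a 3.1-fold lower number from compound 2 to compound 3 (0.50 log units; beyond the scatter). Compound 3 is expected to give about 30000 nM, within a range from 8000 nM to 120000 nM.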

Compound 3, half-maximal inhibitory concentration: 5800 nM
For compound 3 the middle estimate is 5.2-fold (0.71 log units) above the measured one; the whole stated range lies above it.
By their numbers in this assay, from the lowest: compound 3; then compound 1; then compound 2.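

In this assay, 3,5-dichlorophenyl in place of 3-chloro-2-fluorophenyl brings a 16-fold lower number from compound 2 to compound 3 (1.21 log units; beyond the scatter), and in place of 3-chloro-4-fluorophenyl it brings a 2.5-fold lower number from compound 1 to compound 3 (0.39 log units; beyond the scatter). The position on the nitrogen therefore spans a wider range than the first step showed, and compound 3, with both steps beyond the scatter, gives the lowest number of the three. Nothing at hand explains these differences.

The compounds shown leave open whether a single chlorine, a methoxy group or an amine on this phenyl ring would give a lower or a higher number. They also leave open how a bromine in place of either chlorine of compound 3 would read.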